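From Cyclobutyl to Sec-Butyl: A Step Expected Small

The source may hold more compounds than are shown below. What is called first, only, known or untested is meant among the compounds shown, and "the series" means these compounds.

Measured compounds:
Compound 1 `CCCc1ccc(/C=C/C(=O)Nc2ccc3nc(CCC)cc(N)c3c2)cc1`: in a functional assay on HEK293 cells for activation of melanin-concentrating hormone receptor 1 (Homo sapiens), read by inositol phosphate accumulation (a higher number here means that more compound is needed for the effect, a lower number that less compound is needed), compound 1 gives 3600 nM.
Compound 2 `Nc1cc(C2CCC2)nc2ccc(NC(=O)/C=C/c3ccc(C(F)(F)F)cc3)cc12`: in this assay compound 2 gives 250 nM.

Compound 2 stands lowest of the two numbers; compound 1 gives a number far higher, beyond the scatter. Compound 3 `CCC(C)c1cc(N)c2cc(NC(=O)/C=C/c3ccc(C(F)(F)F)cc3)ccc2n1` differs from compound 2 in one place: sec-butyl in place of cyclobutyl on an aromatic carbon. Going by the values given here, no pair of measured compounds isolates this change, and compounds 1 and 2 differ at more than one place, so nothing measured reports on it directly. The two groups hold the same count of carbon, one as a ring and one as a chain. The step is expected to stay within the scatter, a 1.4-fold higher number from compound 2 to compound 3 (0.15 log units; within the scatter). In this assay compound 3 is expected to give 350 nM, between 120 nM and 1000 nM.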

Compound 3, half-maximal effective concentration: 44 nM
Compound 3: middle estimate off by 8.0-fold (0.90 log units), on the high side; the measured number lies below the stated range.
By their numbers in this assay, from the lowest: compound 3; then compound 2; then compound 1.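

In this assay, sec-butyl in place of cyclobutyl on the aromatic carbon next to the ring nitrogen gives a 5.7-fold lower number from compound 2 to compound 3 (0.75 log units; beyond the scatter). The carbon count stays the same across this change, so the number at this position responds to whether those carbons form a ring or a chain. Nothing available explains why the chain gives the lower number. The compounds shown leave open how isopropyl, tert-butyl or a longer chain reads at this carbon. They also leave open whether the step holds with a group other than trifluoromethyl on the far ring.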